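Lengthening the chain: from compound 2 to compound 3

This account rests on a few compounds, and the source may have more. Where it says the series, first, only, none or still open, it means among the compounds named here.

In an assay on microsomes from intestine for inhibition of acyl-CoA:cholesterol acyltransferase (Oryctolagus cuniculus) (a lower number here means a stronger inhibitor, a higher number a weaker inhibitor), compound 1 `CCCCCCSC(=O)CS(=O)(=O)Nc1c(C(C)C)cccc1C(C)C` gives 1000 nM, and compound 2 `CCCCCCCCCCSC(=O)CS(=O)(=O)Nc1c(C(C)C)cccc1C(C)C` gives 130 nM. Compound 2 holds the lowest of the two numbers, set apart by the step of a 7.7-fold lower number from compound 1 to compound 2 (0.89 log units; beyond the scatter). Compound 3 `CCCCCCCCCCCCSC(=O)CS(=O)(=O)Nc1c(C(C)C)cccc1C(C)C` carries ethyl in place of hydrogen on a saturated chain carbon, ten or more bonds along the chain from a sulfur. Within the data shown here, the only measured step that bears on this change, a 7.7-fold lower number from compound 1 to compound 2 (0.89 log units; beyond the scatter), came from a larger addition on the same chain and was modest yet beyond the scatter. A smaller addition is therefore expected to lower the number again, though by less. The expected step is a 1.9-fold lower number from compound 2 to compound 3 (0.27 log units; within the scatter). Compound 3 is estimated at 70 nM in this assay, within 25 nM to 200 nM.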

Compound 3, half-maximal inhibitory concentration: 73 nM
The estimate for compound 3 lay 1.0-fold (0.02 log units) below the measured number; the range from low to high includes it.
By their numbers in this assay, from the lowest: compounds 3 and 2 (each within the scatter of the next); then compound 1.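

Adding ethyl at this place moved the number only within the scatter (a 1.8-fold lower number from compound 2 to compound 3 (0.25 log units; within the scatter)), so in this assay compound 3 cannot be told apart from compound 2. The whole hexyl addition still counts (a 14-fold lower number from compound 1 to compound 3 (1.14 log units; beyond the scatter)), yet the further ethyl brings no change beyond the scatter, unlike the earlier butyl step. No measured evidence accounts for this. The compounds shown leave open how a longer chain, or a carboxylic acid on this chain, would read in this assay.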